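A few compounds are considered here, and "the series" means these few. Any claim that something is new, unique, unknown or untested is made for them only; others in the source may bear on it.

Measured in a functional assay on MCF7 cells (Homo sapiens) for antiproliferative activity, read by MTT assay, with a stated time of 24 h; on this read-out higher numbers stand for weaker inhibition and lower numbers for stronger inhibition:
- compound 1 `CCN(CC)CCNC(=O)C1CC(C(CC)(CC)c2ccc(C#CC(C)(O)CC)c(C)c2)=CN1CC`: 2780 nM
- compound 2 `CCN(CC)CCNC(=O)C1CC=C(C(CC)(CC)c2ccc(C#CC(C)(O)CC)c(C)c2)N1CC`: 600 nM
- compound 3 `CCN(CC)CCNC(=O)C1CC=C(C(CC)(CC)c2ccc(C#CC(O)C3CCCC3)c(C)c2)N1CC`: 1580 nM

Compound 1, at 2780 nM, lies within the scatter of compound 3 and well above compound 2, which gives 600 nM. It therefore sits at the weak end of this small set.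

The next compound, compound 4 `CCN(CC)CCNC(=O)C1CC(C(CC)(CC)c2ccc(/C=C/C(O)(CC)CC)c(C)c2)=CN1CC`, keeps the core of compound 1 and changes only the hydroxylated chain: a group of 8 heavy atoms (7 carbon, 1 oxygen; no ring) in place of a group of 7 heavy atoms (6 carbon, 1 oxygen; no ring), on an aromatic carbon. The group sits on an aromatic carbon, and a triple bond outside aromatic rings gives way to a double bond outside aromatic rings.

Within the data shown here, only one measured step touches this chain: a 2.6-fold higher number from compound 2 to compound 3 (0.42 log units; beyond the scatter). That step is modest, and it alters the hydroxylated end while the triple bond stays in place. Among the measured compounds shown here, no measured compound shows what replacing the triple bond does, so the direction of the change is not established by the data. The modest size of that one step argues only against expecting a large move in this assay. The expected result is a 1.3-fold lower number from compound 1 to compound 4 (0.10 log units; within the scatter), which would be no real step beyond the scatter. For compound 4 the estimated value is 2200 nM, with an expected range from 750 nM to 6500 nM.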

Compound 4, half-maximal inhibitory concentration: 690 nM
For compound 4 the middle estimate is 3.2-fold (0.50 log units) above the measured one; measured number outside the range, below it.
By their numbers in this assay, from the lowest: compounds 2 and 4 (each within the scatter of the next); then compounds 3 and 1 (each within the scatter of the next).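

On the core of compound 1, the chain on the aromatic carbon turns out to be a place where a single change moves the number in this assay beyond the scatter: the swap of the group of 7 heavy atoms with its triple bond for the group of 8 heavy atoms with its double bond gives a 4.0-fold lower number from compound 1 to compound 4 (0.61 log units; beyond the scatter). Among these compounds, this is the first measured step at this chain that removes the triple bond, and it shows that the hydroxylated chain need not keep that bond for the number to fall, at least on this core. Nothing shown explains the step, and no supporting measurement bears on it.

The step changes the bond and the size of the group together, so the compounds shown do not separate the share of each, and they leave open whether the same swap would act alike on the core of compound 2. As far as these compounds go, how an amine in place of the hydroxyl group, or a longer chain at the same aromatic carbon, would read in this assay also remains open.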